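A few compounds are considered here, and "the series" means these few. Any claim that something is new, unique, unknown or untested is made for them only; others in the source may bear on it.

Working notes on the series. Compound 1 `CCN(CC)CCCn1c(=O)/c(=C/c2cc(OC)c(OC)c(OC)c2)s/c1=C1\C(=O)Nc2ccc(Cl)cc21` gives 820 nM in a functional assay on K562 cells (Homo sapiens) for cytotoxicity, read by sulforhodamine B assay, with a stated time of 48 h; on this read-out higher numbers stand for weaker inhibition and lower numbers for stronger inhibition. Among the compounds with values here, compound 2 `CCN(CC)CCCn1c(=O)/c(=C/c2ccc(F)c(F)c2)s/c1=C1/C(=O)Nc2ccc(F)cc21` gives 13400 nM in this assay, the highest of the two numbers so far, with compound 1 sitting a clearly lower number away, beyond the scatter. Compound 3 `CCN(CC)CCCn1c(=O)/c(=C/c2ccc(F)c(F)c2)s/c1=C1\C(=O)Nc2ccc(F)cc21` has not yet been measured. It differs from compound 2 in this way: the two compounds have the same atoms and bonds and differ only in configuration as drawn: 1 of 2 stereo elements differ; a double bond is drawn E in compound 2 and Z in compound 3. Within the data shown here, no step between two measured compounds isolates this change, so its size cannot be read off directly. The only pointer is that the same drawn configuration at that double bond as in compound 3 is carried, alongside other differences, by compound 1, which gives 820 nM. A moderate move toward a lower number is expected for compound 3, with the step from compound 2 to compound 3 estimated at a 2.7-fold lower number from compound 2 to compound 3 (0.43 log units; beyond the scatter). Compound 3 is therefore estimated at 5000 nM in this assay, within a range of 1500 nM to 15000 nM.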

Compound 3, half-maximal inhibitory concentration: 13400 nM
The estimate for compound 3 lay 2.7-fold (0.43 log units) below the measured number; measured number inside the range.
By their numbers in this assay, from the lowest: compound 1; then compounds 2 and 3 (each within the scatter of the next).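

In this assay, changing only the drawing of this double bond from E to Z gives no change at the digits printed from compound 2 to compound 3 (within the scatter). For this pair, the configuration at this double bond therefore moves the number by no more than the scatter, and the sole structural difference in the comparison is plain: the fact that compounds 2 and 3 differ only in the configuration as drawn. Compound 3 shares this drawn configuration with compound 1 yet differs from it in more than one place, so the configuration alone, with the fluorine substituents of compound 3, does not bring the number to that of compound 1.

Still open, on these data alone, is whether the configuration at this double bond matters with the chlorine and the three methoxy groups of compound 1. Also open, as far as these compounds go, is what a morpholine in place of the diethylamine, or a longer chain to that amine, would do to the number.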